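The compounds below may be only part of what the source reports. "The series", "measured", "known", "first", "only" and "open" are said of these compounds alone.

Series notes. Compound 1 `COc1cc(OC)cc(-c2cccc(NC(=O)CCc3ccc4c(c3)COB4O)c2)c1` carries a 3,5-dimethoxyphenyl on the aromatic carbon meta to a large group; in a functional assay on SK-OV-3 cells (Homo sapiens) for antiproliferative activity, read by MTT assay, with a stated time of 72 h (on this read-out lower numbers stand for stronger inhibition and higher numbers for weaker inhibition), compound 1 gives 93000 nM. Compound 2 `CC(=O)c1ccc(-c2cccc(NC(=O)CCc3ccc4c(c3)COB4O)c2)cc1` keeps the same core and differs from compound 1 by 4-acetylphenyl in place of 3,5-dimethoxyphenyl on an aromatic carbon. In this assay compound 2 gives 79000 nM, and the step from compound 1 to compound 2 is a 1.2-fold lower number from compound 1 to compound 2 (0.07 log units; within the scatter).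

Compound 3 `COc1cc(OC)cc(-c2cccc(NC(=O)CCc3cccc4c3COB4O)c2)c1` keeps the 3,5-dimethoxyphenyl of compound 1 but has the other core; the two cores are built from the same atoms joined differently, as set out in a group of 10 heavy atoms (7 carbon, 1 boron, 2 oxygen; one five-membered non-aromatic ring with 2 hetero atoms, one six-membered aromatic ring of carbon only) in place of a group of 10 heavy atoms (7 carbon, 1 boron, 2 oxygen; one five-membered non-aromatic ring with 2 hetero atoms, one six-membered aromatic ring of carbon only), on a saturated chain carbon, two bonds along the chain from a carbonyl carbon. In this assay compound 3 gives 88000 nM, and the step from compound 1 to compound 3 is a 1.1-fold lower number from compound 1 to compound 3 (0.02 log units; within the scatter). Compound 3 stands with compound 1 and compound 2 within the usual scatter, so no order among the three is claimed.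

Compound 4 `CC(=O)c1ccc(-c2cccc(NC(=O)CCc3cccc4c3COB4O)c2)cc1` has not been measured. It differs from compound 3 by 4-acetylphenyl in place of 3,5-dimethoxyphenyl on an aromatic carbon, the same change that separates compound 1 from compound 2, made on the other core; both place lines read word for word alike. The change occurs twice among these compounds. Because the step from compound 1 to compound 2 is a 1.2-fold lower number from compound 1 to compound 2 (0.07 log units; within the scatter), and because the two cores themselves lie within the scatter with a 1.1-fold lower number from compound 1 to compound 3 (0.02 log units; within the scatter), the step from compound 3 to compound 4 is expected to be of similar size, a 1.2-fold lower number from compound 3 to compound 4 (0.07 log units; within the scatter). In this assay compound 4 is expected to give 75000 nM, with the range 40000 nM to 140000 nM estimated for repeated measurements.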

Compound 4, half-maximal inhibitory concentration: 57000 nM
For compound 4 the middle estimate is 1.3-fold (0.12 log units) above the measured one, within the range that was stated.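

In this assay, putting 4-acetylphenyl in place of 3,5-dimethoxyphenyl on the second core gives a 1.5-fold lower number from compound 3 to compound 4 (0.19 log units; within the scatter), and this step agrees with the same change on the first core: the same change on two cores in this assay, a 1.2-fold lower number (0.07 log units; within the scatter) from compound 1 to compound 2 and a 1.5-fold lower number (0.19 log units; within the scatter) from compound 3 to compound 4, 1.3-fold (0.12 log units) apart, within the scatter of two such steps. Exchanging the cores with 4-acetylphenyl in place gives a 1.4-fold lower number from compound 2 to compound 4 (0.14 log units; within the scatter), which likewise agrees with the exchange made with 3,5-dimethoxyphenyl in place: the same change on two cores in this assay, a 1.1-fold lower number (0.02 log units; within the scatter) from compound 1 to compound 3 and a 1.4-fold lower number (0.14 log units; within the scatter) from compound 2 to compound 4, 1.3-fold (0.12 log units) apart, within the scatter of two such steps. Within these four compounds the change therefore carries from one core to the other with no detectable difference, but each of these steps lies within the scatter, so this shows only that neither change moves the number measurably here, not that a change with a large effect would carry across in the same way.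

As far as these compounds go, whether an aryl group bearing an amine or a carboxylic acid, in place of these two groups, would give a step beyond the scatter on either core remains open, as does the effect of a longer chain between the amide carbonyl and the core. From the compounds shown here alone, it is also open whether the agreement between the two cores would hold for such a larger step.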